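Sulfanyl side chain of compound 1: aryl at the carbon bound to sulfur

A few compounds are considered here, and "the series" means these few. Any claim that something is new, unique, unknown or untested is made for them only; others in the source may bear on it.

Compound 1 `CCCSc1nc2nc(C)cc(N3CC[C@@H](C)[C@@H](N(C)c4ncnc5[nH]ccc45)C3)n2n1` carries a propylsulfanyl group on the shared core. In a functional assay on MGC-803 cells (Homo sapiens) for inhibition, read by MTT assay, with a stated time of 72 h (a higher number here means a weaker inhibitor, a lower number a stronger inhibitor), compound 1 gives 15500 nM, the highest of the two numbers recorded in the series; its nearest neighbour is compound 2 `Cc1cc(N2CC[C@@H](C)[C@@H](N(C)c3ncnc4[nH]ccc34)C2)n2nc(SCCc3ccccc3)nc2n1`, which in this assay gives 6190 nM. Compound 3 `Cc1cc(N2CC[C@@H](C)[C@@H](N(C)c3ncnc4[nH]ccc34)C2)n2nc(SCc3csc4ccc(Cl)cc34)nc2n1` reaches only a limit of the assay in this assay, > 100000 nM. Two measured steps start from compound 1: a 2.5-fold lower number from compound 1 to compound 2 (0.40 log units; beyond the scatter), and an at least 6.4-fold higher number from compound 1 to compound 3 (0.80 log units; beyond the scatter). Between the two aryl compounds, an at least 16-fold higher number from compound 2 to compound 3 (1.20 log units; beyond the scatter).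

Compound 4 `Cc1ccc(CSc2nc3nc(C)cc(N4CC[C@@H](C)[C@@H](N(C)c5ncnc6[nH]ccc56)C4)n3n2)cc1` is not yet measured. It differs from compound 1 thus: 4-methylphenyl in place of ethyl on a saturated chain carbon bound to a sulfur. The change resembles the step to compound 3 in placing an aromatic ring on the saturated chain carbon bound to a sulfur, but the ring entering here is a single six-membered carbon ring rather than the bicyclic group of compound 3, and the step to compound 2 shows that an aryl further out on the chain is tolerated. The two measured steps pull in opposite directions, so no step beyond the scatter is firmly expected, with the wider uncertainty towards a higher number. Compound 4 is therefore expected at 14000 nM, within 3500 nM to 60000 nM, which means an expected step of a 1.1-fold lower number from compound 1 to compound 4 (0.04 log units; within the scatter).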

Compound 4, half-maximal inhibitory concentration: 5860 nM
Compound 4: the middle estimate sits 2.4-fold (0.38 log units) above what was measured; the range from low to high includes it.
By their numbers in this assay, from the lowest: compounds 4 and 2 (each within the scatter of the next); then compound 1. At a limit, above all of these: compound 3.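

In this assay, 4-methylphenyl in place of ethyl on a saturated chain carbon bound to a sulfur gives a 2.6-fold lower number from compound 1 to compound 4 (0.42 log units; beyond the scatter), so a single six-membered aromatic ring is accepted at this carbon and the earlier loss with compound 3 does not extend to every aromatic ring placed there. Set against the bicyclic group, the same ring gives an at least 17-fold lower number from compound 3 to compound 4 (1.23 log units; beyond the scatter), which ties that loss, among the compounds shown, to 5-chloro-1-benzothiophen-3-yl and not to the presence of an aromatic ring as such. Benzyl and 4-methylphenyl at this carbon are not told apart, with a 1.1-fold lower number from compound 2 to compound 4 (0.02 log units; within the scatter), so the added chain carbon of compound 2 and the ring methyl of compound 4 leave the two compounds within the scatter of each other.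

Going by these compounds, compound 3 stands at a limit and not at a number, so the full size of its steps stays unknown: the limit of > 100000 nM in this assay, at which 1 of the 4 values shown sits. Open questions are whether the loss with compound 3 follows from the chloro group or from the bicyclic ring itself, and whether an unsubstituted benzyl, a longer chain, an amine or a carboxylic acid at this carbon would shift the number further from that of compound 1.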